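Lengthening the ring-bound methyl to ethyl

The source may report more compounds than this note shows. Statements on the series, on what has been measured and on what is new or still open speak of the compounds shown alone.

Compound 1 `CC(C)(C)C(=O)NCc1ccc(NC(=O)N2CCCC[C@H]2[C@H](O)c2ccc(Cl)c(Cl)c2)cc1` in a functional assay for inhibition, with Homo sapiens as the target (on this read-out higher numbers stand for weaker inhibition and lower numbers for stronger inhibition), gives > 10000 nM, which is a limit of the assay rather than a number. Compound 2 `C[C@H]1CC[C@@H]([C@@H](O)c2ccc(Cl)c(Cl)c2)N1C(=O)Nc1ccc(CNC(=O)C(C)(C)C)cc1` gives 400 nM in this assay. Compound 3 `C[C@@H]1CC[C@@H]([C@@H](O)c2ccc(Cl)c(Cl)c2)N1C(=O)Nc1ccc(CNC(=O)C(C)(C)C)cc1`, its stereoisomer, also gives a limit, > 10000 nM. The step of an at least 25-fold higher number from compound 2 to compound 3 (1.39 log units; beyond the scatter) is large, due to the fact that compounds 2 and 3 differ only in the configuration as drawn; compound 2 thus holds the only number shown, because the limit of > 10000 nM in this assay, at which 2 of the 3 values shown sit, marks both others. Compound 4 `CC[C@H]1CC[C@@H]([C@@H](O)c2ccc(Cl)c(Cl)c2)N1C(=O)Nc1ccc(CNC(=O)C(C)(C)C)cc1` differs from compound 2 by methyl in place of hydrogen on a saturated chain carbon bound to a saturated ring carbon. For the measured compounds named here, no measured step adds a group in this way; the only large measured step concerns configuration, so the expected step of a 1.3-fold higher number from compound 2 to compound 4 (0.10 log units; within the scatter) is small, within the scatter. Compound 4 is therefore estimated at 500 nM, between 150 nM and 2500 nM.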

Compound 4, half-maximal inhibitory concentration: 700 nM
Beside the measured number, compound 4's estimate is 1.4-fold (0.15 log units) below it; measured number inside the range.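

Methyl in place of hydrogen on a saturated chain carbon bound to a saturated ring carbon gives a 1.8-fold higher number from compound 2 to compound 4 (0.24 log units; within the scatter) in this assay, so going from methyl to ethyl here leaves the read-out within the scatter. The earlier compounds shown here showed only that the drawn configuration at this ring carbon can matter; this step shows that, with the configuration of compound 2 kept, the larger ethyl group still gives a measured number rather than a limit. Nothing given here explains why this step is so small. From the compounds shown here alone, whether a longer chain such as propyl, or an amine on the ethyl group, behaves the same way remains open.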